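Swapping the thioether heteroaryl on compound 1

This account rests on a few compounds, and the source may have more. Where it says the series, first, only, none or still open, it means among the compounds named here.

Three analogues sharing one core were tested in a functional assay on C6 cells (Rattus norvegicus) for cytotoxicity, read by MTT assay, with a stated time of 24 h, tested at 25 ug/mL; a lower number here means a stronger effect, a higher number a weaker effect of the compound at the concentration tested. Compound 1 `Cc1ccc(-c2cs/c(=N/NC(=O)CSc3nnnn3-c3ccccc3)n2-c2ccccc2)cc1` gives 38.8%, compound 2 `O=C(CSc1nnnn1-c1ccccc1)N/N=c1/scc(-c2ccccc2)n1-c1ccccc1` gives 42.5%, and compound 3 `O=C(CSc1nnnn1-c1ccccc1)N/N=c1/scc(-c2ccc(Br)cc2)n1-c1ccccc1` gives 47.9%. Compound 1 has the lowest of the three numbers, but the gaps to its neighbours are small: a number 3.7 percentage points higher from compound 1 to compound 2 (within the scatter) and a number 9.1 percentage points higher from compound 1 to compound 3 (within the scatter), with a number 5.4 percentage points higher from compound 2 to compound 3 (within the scatter) between the other two, so the three compounds cannot be separated in this assay.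

Compound 4 `Cc1ccc(-c2cs/c(=N/NC(=O)CSc3nnc(C)s3)n2-c2ccccc2)cc1` differs from compound 1 at another place: 5-methyl-1,3,4-thiadiazol-2-yl in place of 1-phenyl-1H-tetrazol-5-yl on a sulfur. Among the measured compounds shown here, none of the measured steps touches the sulfur-bound group; all three concern the aromatic carbon of the phenyl substituent and were within the scatter. For the measured compounds named here, there is therefore no measured step that bears on the change to compound 4, and the only guide is that the core has so far given numbers in a narrow band.

Compound 4 is expected to land near compound 1, with an estimated step of a number 3.2 percentage points higher from compound 1 to compound 4 (within the scatter) in this assay. The estimate for compound 4 is 42%, with a range from 26% to 60%.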

Compound 4, a percentage reported as activity, at one concentration (the size of the read-out at that concentration, not a potency): 50.1%
Compound 4: the middle estimate sits 8.1 percentage points below what was measured; the range from low to high includes it.
By their numbers in this assay, from the lowest: compounds 1, 2, 3 and 4 (each within the scatter of the next, the first and the last beyond it).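

Unlike the earlier steps, which all concerned an aromatic carbon of the phenyl substituent and stayed within the scatter, placing 5-methyl-1,3,4-thiadiazol-2-yl in place of 1-phenyl-1H-tetrazol-5-yl on a sulfur gives in this assay a number 11.3 percentage points higher from compound 1 to compound 4 (beyond the scatter), the only step in this set beyond the scatter, though a modest one. The group on the sulfur is therefore a place where the read-out of this series can move, and here the exchange goes with a weaker effect at the concentration tested. Nothing measured here accounts for the step.

This single exchange removes the phenyl group and changes the ring together, so the compounds shown cannot say which of the two matters. On these data alone, how a tetrazole carrying methyl instead of phenyl, or a thiadiazole carrying an amine, would behave on the sulfur remains open.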